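Compound 4: 2,6-dichlorophenyl replacing 4-methoxyphenyl

The compounds below may be only part of what the source reports. "The series", "measured", "known", "first", "only" and "open" are said of these compounds alone.

Measured in a functional assay on MDA-MB-231 cells (Homo sapiens) for antiproliferative activity, read by MTT assay, with a stated time of 24 h; on this read-out lower numbers stand for stronger inhibition and higher numbers for weaker inhibition:
- compound 1 `O=C(O)CC(NC(=O)c1c(Cl)cccc1Cl)c1ccccc1`: > 100000 nM (a limit)
- compound 2 `CC(C)(C)c1ccc(C(CC(=O)O)NC(=O)c2ccc(F)cc2)cc1`: 87600 nM
- compound 3 `COc1ccc(C(=O)NC(CC(=O)O)c2ccc(C(C)(C)C)cc2)cc1`: > 100000 nM (a limit)

Compound 3 gives > 100000 nM, which is a limit and not a number. Its place in the series is the limit of > 100000 nM in this assay, at which 2 of the 3 values shown sit.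

The next compound is compound 4 `CC(C)(C)c1ccc(C(CC(=O)O)NC(=O)c2c(Cl)cccc2Cl)cc1`. The change is 2,6-dichlorophenyl in place of 4-methoxyphenyl on a carbonyl carbon. Among the measured compounds shown here, only one measured step touches this part of the molecule, an at least 1.1-fold higher number from compound 2 to compound 3 (0.05 log units; that floor lies within the scatter), with methoxy in place of fluoro on an aromatic carbon. That step offers no sign of a large effect from this group.

Compound 1 also carries 2,6-dichlorophenyl, and its > 100000 nM is likewise a limit. For the measured compounds named here, compound 2 gives 87600 nM, the only actual number, and this sets the range in which a value for compound 4 is most plausible.

In this assay, only a small step is therefore expected, towards a lower number if there is any change, and not clearly beyond the scatter. The expected step is an at least 1.2-fold lower number from compound 3 to compound 4 (0.09 log units; that floor lies within the scatter). A result at the limit remains about as likely as a number. For compound 4 the estimated value is 80000 nM, with an expected range from 30000 nM to 160000 nM.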

Compound 4, half-maximal inhibitory concentration: > 100000 nM
Compound 4: no number, only a limit; the forecaster's own chance of this, stated with the estimate: 50%; middle value at least 1.2-fold (0.09 log units) from the limit.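

In this assay, compound 4 gives > 100000 nM, which is a limit and not a number, so 2,6-dichlorophenyl on a carbonyl carbon now reaches this limit both with the tert-butyl group in compound 4 and without it in compound 1. Among the compounds shown here, the one readable step for this position, 2,6-dichlorophenyl in place of 4-fluorophenyl, is an at least 1.1-fold higher number from compound 2 to compound 4 (0.05 log units; that floor lies within the scatter); it shows no change beyond the scatter, though as a floor it does not fix the true size of the step. The steps to compound 4 from compound 3 and from compound 1 cannot be read, and the series remains largely at a single ceiling: the limit of > 100000 nM in this assay, at which 3 of the 4 values shown sit.

Open, from the compounds shown here alone, is whether a pyridine ring or an aminomethyl chain on the carbonyl carbon would give a number clearly lower than that of compound 2, 87600 nM. Also open, going by these compounds, is whether a methyl ester or a primary amide in place of the carboxylic acid of the shared core would change the result in this assay.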